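The source may report more compounds than this note shows. Statements on the series, on what has been measured and on what is new or still open speak of the compounds shown alone.

Compound 2, `O=c1[nH]cnc2c(CNC(CO)COP(=O)(O)O)c[nH]c12`, is the starting point. In an assay on isolated protein for inhibition of hypoxanthine-guanine phosphoribosyltransferase (Homo sapiens), read by spectrophotometry, in the presence of a further agent that is not named here (on this read-out higher numbers stand for weaker inhibition and lower numbers for stronger inhibition), compound 2 gives > 10000 nM, which is a limit of the assay rather than a measured number. Its two nearest relatives sit at the same limit. Compound 1, `O=c1[nH]cnc2c(CNCCOP(=O)(O)O)c[nH]c12`, lacks the hydroxymethyl of compound 2, and in this assay compound 1 gives > 10000 nM, again a limit. Compound 3, `O=c1[nH]c(Cl)nc2c(CNC(CO)COP(=O)(O)O)c[nH]c12`, adds a chloro to the core of compound 2, and in this assay compound 3 gives > 10000 nM, also a limit. Because all three values sit at the limit of > 10000 nM in this assay, at which 3 of the 3 values shown sit, the step that the two limits leave unreadable from compound 1 to compound 2 and the step that the two limits leave unreadable from compound 2 to compound 3 cannot be read in size or direction. Compound 4, `O=c1[nH]cnc2c(CNC(CO)(CO)COP(=O)(O)O)c[nH]c12`, differs from compound 2 by hydroxymethyl in place of hydrogen on a saturated chain carbon bound to an amine nitrogen and two saturated chain carbons. Within the data shown here, only the step from compound 1 to compound 2 bears on this change, since it adds the same kind of group to the same chain, and its size is unreadable. With no readable step in hand, the expected step that the limit leaves unreadable from compound 2 to compound 4 is set close to nothing beyond the scatter, and the outcome most likely remains at the limit. Compound 4 is therefore expected to give about 15000 nM in this assay, with a plausible range from 5000 nM to 50000 nM.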

Compound 4, inhibition constant: > 10000 nM
Compound 4 ended at the assay's limit; the forecaster's own chance of this, stated with the estimate: 80%; the middle value does not contradict the limit.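

No new step can be read from compound 2 to compound 4, because both compounds sit at the same limit, so neither size nor direction shows: the limit of > 10000 nM in this assay, at which 4 of the 4 values shown sit.
The compounds shown leave open how strongly any of them acts in this assay and whether adding a hydroxymethyl or a chloro changes that in either direction.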